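The source may report more compounds than this note shows. Statements on the series, on what has been measured and on what is new or still open speak of the compounds shown alone.

Compound 1 `O=C(CN1CCN(c2ccccc2)CC1)N1CCN(c2nnc(-c3ccccc3)c(-c3ccccc3)n2)CC1` is a weak inhibitor in an ADME assay on NIH3T3 cells (Mus musculus) for cytotoxicity, read by MTT assay, with a stated time of 24 h; a lower number here means a stronger inhibitor, a higher number a weaker inhibitor: compound 1 reaches only the limit of the measurement, > 963000 nM, and that is one of the two values, as noted at the limit of > 963000 nM in this assay, at which 1 of the 2 values shown sits. Compound 2 `COc1ccccc1N1CCN(CC(=O)N2CCN(c3nnc(-c4ccccc4)c(-c4ccccc4)n3)CC2)CC1` gives 444000 nM in this assay. Compound 3 `COc1cccc(N2CCN(CC(=O)N3CCN(c4nnc(-c5ccccc5)c(-c5ccccc5)n4)CC3)CC2)c1` differs from compound 1 by methoxy in place of hydrogen on an aromatic carbon. For the measured compounds named here, the one measured step that bears on this change is an at least 2.1-fold lower number from compound 1 to compound 2 (0.33 log units; beyond the scatter). Compound 3 is therefore expected to show a similar modest step, an at least 1.9-fold lower number from compound 1 to compound 3 (0.28 log units; that floor lies within the scatter), toward a lower number. Compound 3 is estimated at 500000 nM, with a range from 200000 nM to 963000 nM.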

Compound 3, half-maximal inhibitory concentration: 361000 nM
Compound 3: the middle estimate sits 1.4-fold (0.14 log units) above what was measured; the measured number falls inside the stated range.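

Compound 3 shows that methoxy also lowers the number in this assay when it sits as in the 3-methoxyphenyl group: an at least 2.6-fold lower number from compound 1 to compound 3 (0.42 log units; beyond the scatter). The value of compound 1 is only a limit, so this step has no upper end: the limit of > 963000 nM in this assay, at which 1 of the 3 values shown sits. The further step, a 1.2-fold lower number from compound 2 to compound 3 (0.09 log units; within the scatter), lies within the scatter, so 3-methoxyphenyl and 2-methoxyphenyl cannot be told apart here.

Going by these compounds, the full size of the methoxy step remains open. So does whether an ethoxy group, a chlorine atom or an amine in place of methoxy would give a similar step.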